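This account rests on a few compounds, and the source may have more. Where it says the series, first, only, none or still open, it means among the compounds named here.

Working notes on the series in a functional assay on L1210 cells (Mus musculus) for antiproliferative activity; a lower number here means a stronger inhibitor, a higher number a weaker inhibitor.

For the measured compounds named here, compound 1 `CCOc1ccc(-c2cc(N)c(C(=O)c3cc(OC)c(OC)c(OC)c3)s2)cc1` gives 590 nM in this assay, which is the highest of the three numbers measured so far: compound 3 `COc1ccc(-c2cc(N)c(C(=O)c3cc(OC)c(OC)c(OC)c3)s2)cc1OC` gives 40 nM, and compound 2 `COc1cc(C(=O)c2sc(-c3cccc([N+](=O)[O-])c3)cc2N)cc(OC)c1OC` gives 11 nM. Both measured steps away from compound 1 replace the 4-ethoxyphenyl: a 54-fold lower number from compound 1 to compound 2 (1.73 log units; beyond the scatter), and a 15-fold lower number from compound 1 to compound 3 (1.17 log units; beyond the scatter). Between the two replacements, a 3.6-fold higher number from compound 2 to compound 3 (0.56 log units; beyond the scatter).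

Compound 4 `COc1cc(C(=O)c2sc(-c3ccc(Br)cc3)cc2N)cc(OC)c1OC` is not yet measured. It differs from compound 1 in one place: bromo in place of ethoxy on an aromatic carbon, on an aromatic carbon of a six-membered aromatic ring of carbon only, para to a large group. Neither measured step tests bromo itself; what they show is that replacing the ethoxy-bearing aryl group of compound 1 lowered the number in both cases, once by a large margin and once by a larger one. A lower number for compound 4 is therefore expected, but with less confidence about its size than for a direct repeat of either measured step. The estimate for compound 4 in this assay is 120 nM, with a range of 30 nM to 450 nM, meaning an expected step of a 4.9-fold lower number from compound 1 to compound 4 (0.69 log units; beyond the scatter).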

Compound 4, half-maximal inhibitory concentration: 100 nM
Compound 4: the middle estimate sits 1.2-fold (0.08 log units) above what was measured, and the stated range covers the measured number.
By their numbers in this assay, from the lowest: compound 2; then compound 3; then compound 4; then compound 1.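

For the compounds shown here, compound 4 is the first case in which the phenyl ring stays and only its substituent changes: in this assay, bromo in place of ethoxy gives a lower number (a 5.9-fold lower number from compound 1 to compound 4 (0.77 log units; beyond the scatter)), so this single substituent change is enough to move the number beyond the scatter. The 4-bromophenyl does not match either earlier replacement of the 4-ethoxyphenyl, with higher numbers against both the 3,4-dimethoxyphenyl (a 2.5-fold higher number from compound 3 to compound 4 (0.40 log units; beyond the scatter)) and the 3-nitrophenyl (a 9.1-fold higher number from compound 2 to compound 4 (0.96 log units; beyond the scatter)). No available data bear on the reason for these differences.

Going by these compounds, whether the lower number is specific to bromo remains open, as a chloro, methyl, hydroxy or amino group at this place on the phenyl ring would show. Compounds with a methoxy or propoxy group there would show how the number follows the length of the alkoxy chain.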